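Amide Variation on a Pyrazole HMG-CoA Reductase Inhibitor Series

The source may report more compounds than this note shows. Statements on the series, on what has been measured and on what is new or still open speak of the compounds shown alone.

Compound 1: `CC(C)c1c(C(=O)NCc2ccccc2)nn(-c2ccc(F)cc2)c1OC[C@@H](O)C[C@@H](O)CC(=O)O` — 3.8 nM
Compound 2: `CC(C)c1c(C(=O)N(C)Cc2ccccc2)nn(-c2ccc(F)cc2)c1OC[C@@H](O)C[C@@H](O)CC(=O)O` — 5.2 nM
Compound 3: `Cc1ccc(CN(C)C(=O)c2nn(-c3ccc(F)cc3)c(OC[C@@H](O)C[C@@H](O)CC(=O)O)c2C(C)C)cc1` — 37 nM

Three compounds sharing one core were tested in an assay on microsomes from liver for inhibition of 3-hydroxy-3-methylglutaryl-coenzyme A reductase (Rattus norvegicus); on this read-out higher numbers stand for weaker inhibition and lower numbers for stronger inhibition. Compound 1 gives 3.8 nM and compound 2 gives 5.2 nM in this assay; the step of a 1.4-fold higher number from compound 1 to compound 2 (0.14 log units; within the scatter) is within the scatter. Compound 3 stands highest of the three values at 37 nM; the step of a 7.1-fold higher number from compound 2 to compound 3 (0.85 log units; beyond the scatter) and the step of a 9.7-fold higher number from compound 1 to compound 3 (0.99 log units; beyond the scatter) are both beyond the scatter.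

Compound 4 is `CC(C)c1c(C(=O)N2CCC[C@H](c3ccccc3)C2)nn(-c2ccc(F)cc2)c1OC[C@@H](O)C[C@@H](O)CC(=O)O`. It differs from compound 3 in one place: 3-phenylpiperidin-1-yl in place of methyl(4-methylbenzyl)amino on a carbonyl carbon. Two of the measured steps bear on this change. The step of a 1.4-fold higher number from compound 1 to compound 2 (0.14 log units; within the scatter) shows that a methyl on the amide-type nitrogen changes little, so a tertiary amide in itself need not cost much. The step of a 7.1-fold higher number from compound 2 to compound 3 (0.85 log units; beyond the scatter) shows that the methyl on the aromatic carbon accounts for the weaker value of compound 3; that methyl is absent from compound 4. The expected step is therefore a 2.5-fold lower number from compound 3 to compound 4 (0.39 log units; beyond the scatter), a lower number, though the new ring carries uncertainty. Compound 4 is estimated at 15 nM, with a range from 4 nM to 60 nM.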

Compound 4, half-maximal inhibitory concentration: 4.8 nM
Estimate against measurement, compound 4: 3.1-fold (0.49 log units) above; measured number inside the range.
By their numbers in this assay, from the lowest: compounds 1, 4 and 2 (each within the scatter of the next); then compound 3.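

Tying the amide nitrogen into a ring is compatible with a low number at this position: a 1.1-fold lower number from compound 2 to compound 4 (0.03 log units; within the scatter) and a 1.3-fold higher number from compound 1 to compound 4 (0.10 log units; within the scatter) both stay within the scatter, so in this assay 3-phenylpiperidin-1-yl on the carbonyl carbon cannot be told apart from benzyl(methyl)amino or benzylamino. The step of a 7.7-fold lower number from compound 3 to compound 4 (0.89 log units; beyond the scatter) lies beyond the scatter even though the entering group is the larger one by count of heavy atoms, so among these compounds a larger group on the carbonyl carbon does not in itself go with a higher number; compound 3 remains the one compound set apart from the others. Nothing available here explains why these amide groups give the numbers they do.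

The compounds shown leave open whether the single defined stereocentre of compound 4 matters, since its mirror-image 3-phenylpiperidin-1-yl group does not appear among them. They also leave open whether a methyl on an aromatic carbon of the phenyl ring would raise the number in the ring-closed amide as it does in compound 3, and how a smaller pyrrolidine ring or a 4-phenylpiperidin-1-yl group would read on the same carbonyl carbon.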